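Acyl hydrazide series: 5-methylfuran-2-yl in place of phenyl

The source may report more compounds than this note shows. Statements on the series, on what has been measured and on what is new or still open speak of the compounds shown alone.

Compound 1 `CCNC(=O)[C@H]1O[C@@H](n2cnc3c(NNC(=O)c4ccccc4)ncnc32)[C@H](O)[C@@H]1O` carries a benzoyl on the hydrazide. In a functional assay on CHO cells for activation of adenosine receptor A2b (Homo sapiens), read by cAMP accumulation (a lower number here means that less compound is needed, a higher number that more compound is needed for the effect), compound 1 gives > 5000 nM, which is a limit of the assay and not a number. Compound 2 `CCNC(=O)[C@H]1O[C@@H](n2cnc3c(NNC(=O)c4ccc(Cl)cc4)ncnc32)[C@H](O)[C@@H]1O` in this assay gives > 5000 nM, again a limit and not a number. The step that the two limits leave unreadable from compound 1 to compound 2 is therefore not readable, and both values sit at the limit of > 5000 nM in this assay, at which 2 of the 2 values shown sit. Compound 3 `CCNC(=O)[C@H]1O[C@@H](n2cnc3c(NNC(=O)c4ccc(C)o4)ncnc32)[C@H](O)[C@@H]1O` differs from compound 1 by 5-methylfuran-2-yl in place of phenyl on a carbonyl carbon. Going by the values given here, no measured step touches the carbonyl substituent itself, so nothing shows whether this change moves the read-out; the only measured change, from compound 1 to compound 2, left both values at the limit. Compound 3 is therefore expected to sit at or beyond the same limit, with a step that the limit leaves unreadable from compound 1 to compound 3 as the estimated step. The estimate for compound 3 in this assay is 8000 nM, within 2000 nM to 40000 nM.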

Compound 3, half-maximal effective concentration: 227 nM
Estimate against measurement, compound 3: 35-fold (1.55 log units) above, outside the stated range (below it).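

In this assay the carbonyl substituent proves to be a place where the read-out moves: 5-methylfuran-2-yl in place of phenyl gives an at least 22-fold lower number from compound 1 to compound 3 (1.34 log units; beyond the scatter). The same group in place of 4-chlorophenyl gives an at least 22-fold lower number from compound 2 to compound 3 (1.34 log units; beyond the scatter). Compound 3 is thus the only compound of the three with a readable number, the others remaining at a limit of the assay: the limit of > 5000 nM in this assay, at which 2 of the 3 values shown sit.

The compounds shown do not separate the ring oxygen of 5-methylfuran-2-yl from its methyl group, so it stays open whether furan-2-yl without the methyl, or 5-methylthiophen-2-yl with sulfur in the ring, would keep the read-out of compound 3. Going by these compounds, the step from hydrogen to chloro on the phenyl cannot be read, and how a substituent on the phenyl ring affects the read-out also stays open.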